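The source may hold more compounds than are shown below. What is called first, only, known or untested is meant among the compounds shown, and "the series" means these compounds.

Compound 1 `CCC1CCCN(C(=O)CN2CN(c3ccccc3)C3(CCN(C(=O)c4ccc(C5CCCCC5)cc4)CC3)C2=O)C1` gives 2600 nM in an assay on HEK293 cells for displacement of a labelled ligand from NPC1-like intracellular cholesterol transporter 1 (Homo sapiens); a lower number here means a stronger inhibitor, a higher number a weaker inhibitor.
Compound 2 `CC(C)(C)OC(=O)NCNC(=O)CN1CN(c2ccccc2)C2(CCN(C(=O)c3ccc(C4CCCCC4)cc3)CC2)C1=O` gives 1700 nM in this assay.
Compound 3 `CC1CCCN(C(=O)CN2CN(c3ccccc3)C3(CCN(C(=O)c4ccc(C5CCCCC5)cc4)CC3)C2=O)C1` gives 3600 nM in this assay.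

Compound 3 has the highest of the three numbers; its gap to compound 1 is within the scatter, a 1.4-fold higher number from compound 1 to compound 3 (0.14 log units; within the scatter), while its gap to compound 2 is beyond it, a 2.1-fold higher number from compound 2 to compound 3 (0.33 log units; beyond the scatter). Compound 4 `CS(=O)(=O)NCCNC(=O)CN1CN(c2ccccc2)C2(CCN(C(=O)c3ccc(C4CCCCC4)cc3)CC2)C1=O` differs from compound 3 in one place: (2-(methanesulfonamido)ethyl)amino in place of 3-methylpiperidin-1-yl on a carbonyl carbon. Among the compounds with values here, two measured steps bear on this. Replacing a piperidine by a group with no ring and two hydrogen-bond donors gave a 1.5-fold lower number from compound 1 to compound 2 (0.18 log units; within the scatter), and the reverse exchange gave a 2.1-fold higher number from compound 2 to compound 3 (0.33 log units; beyond the scatter). Compound 4 repeats that kind of exchange from compound 3, with a group that also has no ring and two hydrogen-bond donors, so a modest move toward a lower number is expected, in the order of a 1.9-fold lower number from compound 3 to compound 4 (0.28 log units; within the scatter). Compound 4 is therefore estimated at 1900 nM in this assay, with a range from 900 nM to 4000 nM.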

Compound 4, half-maximal inhibitory concentration: 2100 nM
For compound 4 the middle estimate is 1.1-fold (0.04 log units) below the measured one; measured number inside the range.
By their numbers in this assay, from the lowest: compounds 2, 4, 1 and 3 (each within the scatter of the next, the first and the last beyond it).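

At this carbonyl carbon, (2-(methanesulfonamido)ethyl)amino, a group with no ring, replaces 3-methylpiperidin-1-yl (a 1.7-fold lower number from compound 3 to compound 4 (0.23 log units; within the scatter)) and 3-ethylpiperidin-1-yl (a 1.2-fold lower number from compound 1 to compound 4 (0.09 log units; within the scatter)), so in this assay it cannot be told apart from either piperidine. Changing the end of the open chain, with (methanesulfonamido)methyl in place of (tert-butoxycarbonyl)amino (a 1.2-fold higher number from compound 2 to compound 4 (0.09 log units; within the scatter)), also leaves the number within the scatter, so these two different open chains cannot be told apart either. Nothing available explains these results.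

The compounds shown leave open whether a primary amine or a carboxylic acid at the end of this chain, or a longer chain, would move the number beyond the scatter. They also leave open whether these exchanges would read the same on a different core.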